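The compounds below may be only part of what the source reports. "The series", "measured", "known", "first", "only" and "open" are said of these compounds alone.

compound 1 `CCOC(=O)Nc1cc(NC(C)CCCN(CC)CC)c2nc(C)c(C)nc2n1`: > 40000 nM, a limit
compound 2 `CCOC(=O)Nc1cc(NCCCCN(CC)CC)c2nc(-c3cccs3)c(-c3cccs3)nc2n1`: > 40000 nM, a limit
compound 3 `CCOC(=O)Nc1cc(NCCN(CC)CC)c2nc(-c3ccccc3)c(-c3ccccc3)nc2n1`: 2700 nM

In an ADME assay on Vero cells (Chlorocebus sabaeus) for cytotoxicity, read by CellTiter-Glo, with a stated time of 72 h (a higher number here means that more compound is tolerated, a lower number that less compound is tolerated), compound 2 gives only a limit and not a number. For compound 2 that is the limit of > 40000 nM in this assay, at which 2 of the 3 values shown sit. Compound 4 `CCOC(=O)Nc1cc(NCCN(CC)CC)c2nc(-c3cccs3)c(-c3cccs3)nc2n1` departs from compound 2 by diethylamino in place of 2-(diethylamino)ethyl on a saturated chain carbon, two bonds along the chain from a nitrogen on an aromatic ring, on a saturated chain carbon, two bonds along the chain from a nitrogen on an aromatic ring. Within the data shown here, no measured pair shows this change directly. Among the measured compounds shown here, a clear move towards less compound tolerated, beyond the scatter, is expected in this assay because compound 3 gives 2700 nM, the only number in the set. The estimated step is an at least 5.7-fold lower number from compound 2 to compound 4 (0.75 log units; beyond the scatter). Compound 4 is estimated at 7000 nM, with an expected range of 2500 nM to 30000 nM.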

Compound 4, half-maximal cytotoxic concentration: 6300 nM
For compound 4 the middle estimate is 1.1-fold (0.05 log units) above the measured one, within the range that was stated.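

In this assay, going from (4-(diethylamino)butyl)amino to (2-(diethylamino)ethyl)amino on the shared core gives an at least 6.3-fold lower number from compound 2 to compound 4 (0.80 log units; beyond the scatter). Among these compounds, this is the first pair that isolates the chain at this place, and the shorter chain is the less tolerated. The true size of the step stays open, since compound 2 gives only a limit: the limit of > 40000 nM in this assay, at which 2 of the 4 values shown sit.

A 3-(diethylamino)propyl chain at this place would show whether the change is gradual or abrupt. A dimethylamino group in place of diethylamino would show whether the amine matters alongside chain length.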